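This account rests on a few compounds, and the source may have more. Where it says the series, first, only, none or still open, it means among the compounds named here.

Compound 3 `CC(C)c1n[nH]c2c(NCc3ccc(-c4ccccn4)cc3)nc(SCC(N)=O)nc12` gives the lowest number of the three in a functional assay on HT cells (Homo sapiens) for antiproliferative activity, read by fluorescence, with a stated time of 72 h (on this read-out higher numbers stand for weaker inhibition of growth and lower numbers for stronger inhibition of growth), at 192 nM. Compound 1 `CC(C)c1n[nH]c2c(NCc3ccc(-c4ccccn4)cc3)nc(SCCNC(=N)N)nc12` gives 390 nM in this assay, and compound 2 `CSc1nc(NCc2ccc(-c3ccccn3)cc2)c2[nH]nc(C(C)C)c2n1` gives 783 nM. Compound 4 `CC(C)c1n[nH]c2c(NCc3ccc(-c4ccccn4)cc3)nc(SCCCN(C)C)nc12` differs from compound 3 by 2-(dimethylamino)ethyl in place of carbamoyl on a saturated chain carbon bound to a sulfur. Going by the values given here, two measured steps bear on this change: a 2.0-fold lower number from compound 1 to compound 3 (0.31 log units; beyond the scatter) and a 4.1-fold lower number from compound 2 to compound 3 (0.61 log units; beyond the scatter). Both put carbamoyl onto the same saturated chain carbon bound to a sulfur and lowered the number. Removing carbamoyl again is therefore expected to raise the number, and the closest comparison is compound 1, which also carries a chain at that place and gives 390 nM. The expected step is a 1.8-fold higher number from compound 3 to compound 4 (0.26 log units; within the scatter). Compound 4 is estimated at 350 nM, within a range from 150 nM to 900 nM.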

Compound 4, concentration for 50% growth inhibition: 105 nM
Compound 4: middle estimate off by 3.3-fold (0.52 log units), on the high side; the measured number lies below the stated range.
By their numbers in this assay, from the lowest: compounds 4 and 3 (each within the scatter of the next); then compounds 1 and 2 (each within the scatter of the next).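

In this assay, 2-(dimethylamino)ethyl can stand in place of carbamoyl with a 1.8-fold lower number from compound 3 to compound 4 (0.26 log units; within the scatter) as the result, so these two groups cannot be told apart at this saturated chain carbon bound to a sulfur. The same group in place of hydrogen gives a 7.5-fold lower number from compound 2 to compound 4 (0.87 log units; beyond the scatter) and thus extends what carbamoyl showed to a group with no hydrogen-bond donors. Chains here are not interchangeable, since the chain of compound 1 and that of compound 4 are separated by a 3.7-fold lower number from compound 1 to compound 4 (0.57 log units; beyond the scatter) in this comparison.

On these data alone, whether a carboxylic acid or a longer chain ending in a primary amine would match compound 4 remains open. Nothing given here explains these differences.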